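Carbamate selenocyanate cytotoxicity: chloro replaces methoxy

This account rests on a few compounds, and the source may have more. Where it says the series, first, only, none or still open, it means among the compounds named here.

Compound 1 `COc1ccc(OC(=O)Nc2ccc([Se]C#N)cc2)cc1` carries a methoxy group on the phenyl carbamate and a selenocyanate on the aniline ring. In an ADME assay on 184B5 cells (Homo sapiens) for cytotoxicity, read by MTT assay, with a stated time of 72 h (on this read-out lower numbers stand for stronger inhibition of growth and higher numbers for weaker inhibition of growth), compound 1 gives 19200 nM, which places it second highest among the three measured numbers. Its two neighbours are diselenide-bridged bis-carbamates: compound 2 `CCOC(=O)Nc1ccc([Se][Se]c2ccc(NC(=O)OCC)cc2)cc1` gives 16700 nM and compound 3 `CCCCOC(=O)Nc1ccc([Se][Se]c2ccc(NC(=O)OCCCC)cc2)cc1` gives 26000 nM in this assay. The gap from compound 1 to either of them lies within the usual scatter, so the three compounds cannot be told apart on these numbers alone.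

Compound 4 `N#C[Se]c1ccc(NC(=O)Oc2ccc(Cl)cc2)cc1` keeps the carbamate and the selenocyanate of compound 1 and differs only in one place: chloro in place of methoxy on an aromatic carbon. Among the compounds with values here, no measured pair shows what such an exchange does on this read-out, so there is nothing to set a direction from. The step from compound 1 is therefore expected to stay within the scatter, as a 1.0-fold lower number from compound 1 to compound 4 (0.00 log units; within the scatter). Compound 4 is expected to give about 19000 nM in this assay, with a likely range from 9000 nM to 40000 nM.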

Compound 4, concentration for total growth inhibition: 19900 nM
The estimate for compound 4 lay 1.0-fold (0.02 log units) below the measured number; measured number inside the range.
By their numbers in this assay, from the lowest: compounds 2, 1, 4 and 3 (each within the scatter of the next).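

Within the data shown here, this is the first pair in the set that differs in one place only. In this assay, chloro in place of methoxy on an aromatic carbon, para to a large group, gives a 1.0-fold higher number from compound 1 to compound 4 (0.02 log units; within the scatter), so the two compounds cannot be told apart and this position accepts the exchange without a readable difference on this read-out. Nothing measured here bears on why the two groups read alike.

The compounds shown leave open whether this position stays as quiet with a group of another kind, such as an amine or a carboxylic acid, in the same place. They also leave open whether a longer chain on the oxygen there would stay within the scatter of compound 1.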